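The compounds below may be only part of what the source reports. "The series", "measured", "known", "first", "only" and "open" are said of these compounds alone.

Three compounds have been measured in an ADME assay on RAW264.7 cells (Mus musculus) for cytotoxicity, read by MTT assay, with a stated time of 48 h; a higher number here means that more compound is tolerated, a lower number that less compound is tolerated:

Compound 1 `CC(=O)OC[C@H]1O[C@H](OC[C@H](Cn2cc(-c3ccc(-c4noc(NC5CCCCC5)n4)cc3)nn2)OC(C)=O)C=C[C@@H]1OC(C)=O` gives 16.3 ug/mL.
Compound 2 `CC(=O)OC[C@H]1O[C@H](OC[C@@H](Cn2cc(CN(c3nc(-c4cccc(C)c4)no3)C3CCCCC3)nn2)OC(C)=O)C=C[C@@H]1OC(C)=O` gives 46.4 ug/mL.
Compound 3 `C#CCN(c1nc(-c2ccc(Cl)cc2)no1)C1CCCCC1` gives 15.1 ug/mL.

Compound 3 stands at the lowest of the three numbers. Its nearest neighbour is compound 1, whose number is within the scatter of it, so the two cannot be told apart on these data. The furthest is compound 2, which tolerates more compound by a margin that lies beyond the scatter.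

The next compound, compound 4 `C#CCN(c1nc(-c2ccccc2)no1)C1CCCCC1`, is compound 3 with one change: hydrogen in place of chloro on an aromatic carbon. Among the compounds with values here, no pair of measured compounds differs by this kind of change, so there is no measured step to lean on. A change of this size, a single heavy atom swapped for hydrogen at the edge of the molecule, is expected to move this assay little, most likely within the scatter, with at most a slight shift towards more compound being tolerated. The step from compound 3 to compound 4 is therefore estimated as a 1.3-fold higher number from compound 3 to compound 4 (0.12 log units; within the scatter). For compound 4 the expected value is 20 ug/mL, with a range from 8 ug/mL to 50 ug/mL.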

Compound 4, half-maximal cytotoxic concentration: 32.1 ug/mL
Estimate against measurement, compound 4: 1.6-fold (0.21 log units) below, and the stated range covers the measured number.
By their numbers in this assay, from the lowest: compounds 3, 1, 4 and 2 (each within the scatter of the next, the first and the last beyond it).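

In this assay, within the data shown here, the change from 4-chlorophenyl to phenyl gives a 2.1-fold higher number from compound 3 to compound 4 (0.33 log units; beyond the scatter) and is the first single change that can be read on its own. It shows that one chlorine on this ring, para to a large group, is enough to move the number modestly beyond the usual scatter, with the compound lacking it being tolerated at a higher concentration. The earlier compounds differ from each other in several places at once and could not show this, and nothing measured here explains why the number moves.

Still open, as far as these compounds go, is whether any other group at this place, such as fluoro or methoxy, would give a number like that of chloro or of hydrogen. Also open, from the compounds shown here alone, is whether the same change would move the number equally in the larger frameworks of compound 1 and compound 2.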